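Swapping Methyl for Chloro on Two Related Cores

The compounds below may be only part of what the source reports. "The series", "measured", "known", "first", "only" and "open" are said of these compounds alone.

Compound 1, `Cc1ccccc1N1CCCC(=O)N1`, in an assay on isolated protein for inhibition of Polyunsaturated fatty acid 5-lipoxygenase (Homo sapiens) (a lower number here means a stronger inhibitor, a higher number a weaker inhibitor), gives 57000 nM.
Compound 2, `O=C1CCCN(c2ccccc2Cl)N1`, in this assay gives 99000 nM.
Compound 3, `Cc1ccccc1N1CCC(=O)N1`, in this assay gives 8200 nM.

Compound 3 stands lowest of the three; the difference between its core and the core of compound 1 is not broken down here. Compound 4, `O=C1CCN(c2ccccc2Cl)N1`, is not yet measured. It differs from compound 3 in one place: chloro in place of methyl on an aromatic carbon. The same kind of change occurs once more among these compounds, from compound 1 to compound 2: chloro in place of methyl on an aromatic carbon. The two places are not identical: in the earlier pair the change sits ortho to a group of 7 heavy atoms, in the new pair ortho to a group of 6 heavy atoms. That earlier change gave a 1.7-fold higher number from compound 1 to compound 2 (0.24 log units; within the scatter). A step of similar size is expected in this assay, namely a 1.7-fold higher number from compound 3 to compound 4 (0.23 log units; within the scatter), because the earlier pair showed a 1.7-fold higher number from compound 1 to compound 2 (0.24 log units; within the scatter). Compound 4 is therefore estimated at 14000 nM, likely between 5000 nM and 40000 nM.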

Compound 4, half-maximal inhibitory concentration: 3700 nM
Compound 4: middle estimate off by 3.8-fold (0.58 log units), on the high side; the measured number lies below the stated range.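

Swapping methyl for chloro in this assay gives a 2.2-fold lower number from compound 3 to compound 4 (0.35 log units; beyond the scatter), a modest step towards stronger inhibition. The same swap on the other core does not give a matching result, and the gap between the two steps is larger than repeat measurements would explain: the same change on two cores in this assay, a 1.7-fold higher number (0.24 log units; within the scatter) from compound 1 to compound 2 and a 2.2-fold lower number (0.35 log units; beyond the scatter) from compound 3 to compound 4, 3.8-fold (0.59 log units) apart, beyond the scatter of two such steps. So a step measured on one of these cores cannot simply be carried over to the other, although two pairs alone do not show why the cores differ.

From the compounds shown here alone, it remains open whether a bromo group or an amine in place of the methyl would also separate the two cores. Going by these compounds, how the methyl-to-chloro swap behaves on any further core also remains open.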